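A few compounds are considered here, and "the series" means these few. Any claim that something is new, unique, unknown or untested is made for them only; others in the source may bear on it.

Compound 1 `Cc1cc(=O)oc2cc(OCc3nc(N)nc(Nc4cccc(Cl)c4)n3)ccc12`: 1110 nM
Compound 2 `Cc1cc(=O)oc2cc(OCc3nc(N)nc(Nc4ccc5c(c4)COC5)n3)ccc12`: 1330 nM

In an assay on COS-7 cells for agonist activity at Free fatty acid receptor 1 (Homo sapiens), read by scintillation counting and inositol phosphate accumulation, with a stated time of 90 min (a higher number here means that more compound is needed for the effect, a lower number that less compound is needed), compound 1 gives 1110 nM, the lowest of the two numbers; compound 2 gives 1330 nM, and a 1.2-fold higher number from compound 1 to compound 2 (0.08 log units; within the scatter). Compound 3 `CCc1ccc(Nc2nc(N)nc(COc3ccc4c(C)cc(=O)oc4c3)n2)cc1Cl` differs from compound 1 by ethyl in place of hydrogen on an aromatic carbon, so that 3-chlorophenyl becomes 3-chloro-4-ethylphenyl. Going by the values given here, the only measured step, from compound 1 to compound 2, concerns the whole aryl group on the amine, not this added ethyl, so no step directly bears on it. Without such evidence the expected change in this assay is none beyond the scatter, and compound 3 is estimated at 900 nM (range 300 nM to 2700 nM), an expected step of a 1.2-fold lower number from compound 1 to compound 3 (0.09 log units; within the scatter).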

Compound 3, half-maximal effective concentration: 160 nM
For compound 3 the middle estimate is 5.6-fold (0.75 log units) above the measured one, and the stated range ends above it.
By their numbers in this assay, from the lowest: compound 3; then compounds 1 and 2 (each within the scatter of the next).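

In this assay, ethyl on the aromatic carbon ortho to the chloro group gives a 6.9-fold lower number from compound 1 to compound 3 (0.84 log units; beyond the scatter), so this position responds to a small added chain, whereas the earlier exchange of the whole aryl group gave only a 1.2-fold higher number from compound 1 to compound 2 (0.08 log units; within the scatter). The 3-chloro-4-ethylphenyl group also separates from the aryl group of compound 2, with an 8.3-fold lower number from compound 2 to compound 3 (0.92 log units; beyond the scatter). No measurement shown here accounts for this change. The compounds shown leave open whether methyl, propyl or methoxy at this position would do the same, and whether 4-ethylphenyl without the chloro group would keep the lower number.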